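This account rests on a few compounds, and the source may have more. Where it says the series, first, only, none or still open, it means among the compounds named here.

Measured so far:
- compound 1 `CC1CCN(C2CCN(S(=O)(=O)c3nccn3C)CC2)CC1`: > 10000 nM
- compound 2 `CC1CCN(C2CCN(S(=O)(=O)c3cn(C)cn3)CC2)CC1`: > 10000 nM

In an ADME assay on HCT-116 cells (Homo sapiens) for cytotoxicity, read by CellTiter-Glo, with a stated time of 72 h (a lower number here means a stronger inhibitor, a higher number a weaker inhibitor), compound 2 gives > 10000 nM, which is a limit of the assay and not a number. Compound 1 gives > 10000 nM, which is likewise a limit. Neither compound therefore has a measured potency, and the evidence so far is the limit of > 10000 nM in this assay, at which 2 of the 2 values shown sit.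

The next compound is compound 3 `CC1CCN(C2CCN(S(=O)(=O)c3ccc(F)cc3F)CC2)CC1`, which carries 2,4-difluorophenyl in place of 1-methyl-1H-imidazol-4-yl on a sulfonyl sulfur.

For the measured compounds named here, the only measured step is a step that the two limits leave unreadable from compound 1 to compound 2. It gives no size to carry forward, and it exchanges one methylimidazolyl attachment for another, so it does not cover the arrival of a carbon-only ring. The data therefore support no expected step beyond the usual scatter in this assay, and they favour no direction. The assay may well report only a limit again.

Compound 3 is estimated at 15000 nM, with an expected range from 6000 nM to 40000 nM. This estimate corresponds to an expected step that the limit leaves unreadable from compound 2 to compound 3.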

Compound 3, half-maximal inhibitory concentration: > 5000 nM
Compound 3 was reported as a limit; the forecaster's own chance of this, stated with the estimate: 80%; the middle value is on the limit's open side.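

In this assay compound 3 gives > 5000 nM, which is a limit of the assay and not a number. For the compounds shown here, no step among compound 1, compound 2 and compound 3 can be read. The compounds shown leave open how large the potency of any of them is, and whether the group on the sulfonyl sulfur changes it.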